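Iodo in place of furan-3-yl on the five-membered ring

This account rests on a few compounds, and the source may have more. Where it says the series, first, only, none or still open, it means among the compounds named here.

Measured in a functional assay on K562 cells (Homo sapiens), read by MTT assay, with a stated time of 72 h; on this read-out higher numbers stand for weaker inhibition and lower numbers for stronger inhibition:
compound 1 `COc1ncnc2c1c(-c1ccoc1)cn2[C@@H]1O[C@H](CO)[C@@H](O)[C@H]1O` gives 2820 nM
compound 2 `CN(C)c1ncnc2c1c(-c1ccoc1)cn2[C@@H]1O[C@H](CO)[C@@H](O)[C@H]1O` gives 14900 nM
compound 3 `COc1nc(N)nc2c1c(-c1ccoc1)cn2[C@@H]1O[C@H](CO)[C@@H](O)[C@H]1O` gives > 20000 nM, a limit of this assay the limit of > 20000 nM in this assay, at which 1 of the 3 values shown sits.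

Compound 1 holds the lowest of the two numbers shown. The steps of a 5.3-fold higher number from compound 1 to compound 2 (0.72 log units; beyond the scatter) and an at least 7.0-fold higher number from compound 1 to compound 3 (0.85 log units; beyond the scatter) both alter a group on an aromatic carbon away from the position varied here, so neither bears directly on the change to compound 4 `COc1ncnc2c1c(I)cn2[C@@H]1O[C@H](CO)[C@@H](O)[C@H]1O`, which is iodo in place of furan-3-yl on an aromatic carbon. Going by the values given here, with no measured step at that position, the expectation rests only on the size of the group removed, and a weakening beyond the scatter is expected rather than none. Compound 4 is thus expected near 10000 nM, within 2500 nM to 40000 nM. The expected step is a 3.5-fold higher number from compound 1 to compound 4 (0.55 log units; beyond the scatter).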

Compound 4, half-maximal inhibitory concentration: 14800 nM
Compound 4: the middle estimate sits 1.5-fold (0.17 log units) below what was measured, and the stated range covers the measured number.
By their numbers in this assay, from the lowest: compound 1; then compounds 4 and 2 (each within the scatter of the next). At a limit, above all of these: compound 3.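

In this assay, iodo in place of furan-3-yl gives a 5.2-fold higher number from compound 1 to compound 4 (0.72 log units; beyond the scatter). This aromatic carbon of the five-membered ring is therefore not indifferent to its substituent: here the furan-3-yl ring gives the lower number and the single iodine atom the higher one. No measurement shown gives a reason for this step. From the compounds shown here alone, whether another ring, such as thiophen-3-yl or phenyl, would match furan-3-yl at this position remains open. So does the effect of a small methyl group or an amine there.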